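Step from compound 1 to compound 4: working estimate

The source may report more compounds than this note shows. Statements on the series, on what has been measured and on what is new or still open speak of the compounds shown alone.

Compound 1, `Cc1nc(N(C)C(=O)NC(=O)c2c(F)cccc2F)sc1C(=O)N/N=C/c1ccc(C(F)(F)F)cc1`, in a functional assay on HepG2 cells (Homo sapiens) for inhibition, read by MTT assay, with a stated time of 72 h (on this read-out higher numbers stand for weaker inhibition and lower numbers for stronger inhibition), gives > 100 ug/mL, which is a limit of the assay and not a number.
Compound 2, `CN(C(=O)NC(=O)c1ccc(Cl)c(Cl)c1)c1nc(C(F)(F)F)c(C(=O)N/N=C/c2cccc([N+](=O)[O-])c2)s1`, in this assay gives 7.98 ug/mL.
Compound 3, `CN(C(=O)NC(=O)c1c(F)cccc1F)c1nc(C(F)(F)F)c(C(=O)N/N=C/c2ccc(C(F)(F)F)cc2)s1`, in this assay gives 49.6 ug/mL.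

Compound 1 stands at the weak end of what is shown: only a range is known for it, so its place can be fixed no closer than the limit itself (the limit of > 100 ug/mL in this assay, at which 1 of the 3 values shown sits). Compound 2 and compound 3 each give a number.

Among the compounds with values here, the one measured step between compounds differing in a single place is an at least 2.0-fold lower number from compound 1 to compound 3 (0.30 log units; that floor lies within the scatter). That change sits on the core, not on the 4-(trifluoromethyl)phenyl of the hydrazone, so it does not touch the position now in question.

Compound 4, `Cc1nc(N(C)C(=O)NC(=O)c2c(F)cccc2F)sc1C(=O)N/N=C/c1ccccc1`, differs from compound 1 as follows: hydrogen in place of trifluoromethyl on an aromatic carbon. Within the data shown here, no measured step bears directly on this change. The step from compound 1 to compound 3 only shows that a single change near compound 1 moved the number by an amount at the floor of the scatter. No step beyond the scatter is therefore expected in this assay in either direction, and a limit is again the most likely outcome. Compound 4 is estimated at 120 ug/mL, within 40 ug/mL to 400 ug/mL. The implied step, a step that the limit leaves unreadable from compound 1 to compound 4, is expected to stay within the scatter.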

Compound 4, half-maximal inhibitory concentration: 54.3 ug/mL
Compound 4: middle estimate off by 2.2-fold (0.34 log units), on the high side; low and high end bracket the measured number.
By their numbers in this assay, from the lowest: compound 2; then compounds 3 and 4 (each within the scatter of the next). At a limit, above all of these: compound 1.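

In this assay, the change from 4-(trifluoromethyl)phenyl to phenyl amounts to an at least 1.8-fold lower number from compound 1 to compound 4 (0.26 log units; that floor lies within the scatter). With hydrogen at this place, para to a large group, the core of compound 1 gives a number: compound 4 gives 54.3 ug/mL, so the trifluoromethyl is not required for a value to be read on this core in this assay. The true size of the step stays unread and may exceed its floor, because compound 1 carries only a limit and no number: the limit of > 100 ug/mL in this assay, at which 1 of the 4 values shown sits.

The compounds shown hold only trifluoromethyl and hydrogen at this place on the core of compound 1, so it remains open whether a methoxy group, an amine or a carboxylic acid there would move the number in either direction. Going by these compounds, it also remains open whether the change from 4-(trifluoromethyl)phenyl to phenyl would read the same on the core of compound 3, which carries trifluoromethyl in place of methyl and gives a number of its own.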